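The compounds below may be only part of what the source reports. "The series", "measured", "known", "first", "only" and "open" are said of these compounds alone.

Compound 1 `Cc1cc(-c2ccccc2)n(/C(N)=N/S(=O)(=O)c2cc(C)c(Cl)cc2SCc2cccc(C(F)(F)F)c2)n1` was tested in a functional assay on MCF7 cells (Homo sapiens) for cytotoxicity, read by MTT assay, with a stated time of 72 h (a higher number here means a weaker inhibitor, a lower number a stronger inhibitor), where compound 1 gives 41000 nM. Among the three compounds measured this is the highest number. Compound 2 `Cc1cc(S(=O)(=O)/N=C(\N)n2nccc2-c2ccccc2)c(SCc2ccccc2)cc1Cl` gives 20000 nM in this assay, and compound 3 `Cc1cc(S(=O)(=O)/N=C(\N)n2nccc2-c2ccccc2)c(SCc2cccc(C(F)(F)F)c2)cc1Cl` gives 17000 nM. The step from compound 1 to compound 3, which removes a methyl from an aromatic carbon of the shared core, shows a 2.4-fold lower number from compound 1 to compound 3 (0.38 log units; beyond the scatter). The step from compound 2 to compound 3, which adds a trifluoromethyl on the benzyl ring bound to the sulfur, shows a 1.2-fold lower number from compound 2 to compound 3 (0.07 log units; within the scatter).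

Compound 4 `Cc1cc(-c2ccccc2)n(/C(N)=N/S(=O)(=O)c2cc(C)c(Cl)cc2SCc2ccc(Cl)cc2)n1` has not yet been measured. It differs from compound 1 in one place: 4-chlorophenyl in place of 3-(trifluoromethyl)phenyl on a saturated chain carbon bound to a sulfur. Among the measured compounds shown here, of the measured steps, only the one from compound 2 to compound 3 touches this benzyl ring, and that step stayed within the scatter, so a swap of groups on the same ring is expected to move the number little, if at all. Compound 4 is therefore expected to show a 1.2-fold lower number from compound 1 to compound 4 (0.07 log units; within the scatter), giving an estimated 35000 nM with a range from 15000 nM to 80000 nM.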

Compound 4, half-maximal inhibitory concentration: 108000 nM
Beside the measured number, compound 4's estimate is 3.1-fold (0.49 log units) below it, outside the stated range (above it).
By their numbers in this assay, from the lowest: compounds 3 and 2 (each within the scatter of the next); then compound 1; then compound 4.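

The benzyl ring bound to the sulfur is not a silent position: in this assay the change to 4-chlorophenyl gives a 2.6-fold higher number from compound 1 to compound 4 (0.42 log units; beyond the scatter) on the methyl-bearing core, while the trifluoromethyl step on the core without that methyl, a 1.2-fold lower number from compound 2 to compound 3 (0.07 log units; within the scatter), stayed small. The new change alters both the group and its printed place on the ring, so this one step cannot show which of the two matters. Nothing available explains why the number rose.

The compounds shown leave open whether 4-chlorophenyl would have the same effect on the core without the methyl, as in compound 3. They also leave open how a methoxy group or an amine on this ring would compare with chlorine and trifluoromethyl.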